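Compound 3 and the Step to a 4-Bromophenyl Group

The source may hold more compounds than are shown below. What is called first, only, known or untested is meant among the compounds shown, and "the series" means these compounds.

Measured so far in a functional assay on MCF7 cells (Homo sapiens); on this read-out higher numbers stand for weaker inhibition of growth and lower numbers for stronger inhibition of growth
- Compound 1 `O=S(=O)(/C=C/c1ccc(Cl)cc1)Cc1ccc(Nc2ncnc3ccccc23)cc1` gives 52000 nM
- Compound 2 `O=S(=O)(/C=C/c1ccc(Br)cc1)Cc1ccc(Nc2ncnc3ccc(Br)cc23)cc1` gives 5000 nM
- Compound 3 `COc1cc2ncnc(Nc3ccc(CS(=O)(=O)/C=C/c4ccc(Cl)cc4Cl)cc3)c2cc1OC` gives 11000 nM

Compound 3 holds the middle place of these three numbers, higher than compound 2 and lower than compound 1, with both gaps beyond the usual scatter. Compound 4 `COc1cc2ncnc(Nc3ccc(CS(=O)(=O)/C=C/c4ccc(Br)cc4)cc3)c2cc1OC` keeps the core of compound 3 but carries 4-bromophenyl in place of 2,4-dichlorophenyl on a double-bonded chain carbon bound to a double-bonded chain carbon. Among the measured compounds shown here, no two measured compounds differ in one place alone, so the data offer no direct guide to this change. The expectation therefore stays near compound 3 (11000 nM), with no step beyond the scatter in this assay in either direction. The expected size is a 1.1-fold lower number from compound 3 to compound 4 (0.04 log units; within the scatter) and stays within the scatter. The estimated value for compound 4 is 10000 nM with an expected range from 3500 nM to 30000 nM in this read-out.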

Compound 4, concentration for 50% growth inhibition: 32000 nM
Compound 4: the middle estimate sits 3.2-fold (0.51 log units) below what was measured; measured number above the stated range.
By their numbers in this assay, from the lowest: compound 2; then compound 3; then compounds 4 and 1 (each within the scatter of the next).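

Among the compounds shown here, the pair gives the first comparison on a shared core that differs in one place: 4-bromophenyl in place of 2,4-dichlorophenyl on a double-bonded chain carbon bound to a double-bonded chain carbon gives a 2.9-fold higher number from compound 3 to compound 4 (0.46 log units; beyond the scatter) in this assay. Growth inhibition is therefore weaker with this change, and the group at this place affects the read-out. Nothing available explains the step.

From the compounds shown here alone, whether 4-chlorophenyl on this core would stand with compound 3 or with compound 4 remains open. Going by these compounds, the effect of a methoxy group or an amine on this phenyl ring also remains open.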